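Sec-butyl in place of 1-phenylethyl on the urea nitrogen

A few compounds are considered here, and "the series" means these few. Any claim that something is new, unique, unknown or untested is made for them only; others in the source may bear on it.

Measured so far:
compound 1, `CC[C@H](C)[C@H](NC(=O)N1CCC2(CC1)C(=O)N(c1cccc(F)c1)C2c1ccc(Cl)cc1)C(=O)OC`, 45 nM; 872 nM (2 entries)
compound 2, `C[C@@H](NC(=O)N1CCC2(CC1)C(=O)N(c1cccc(F)c1)C2c1ccc(Cl)cc1)c1ccccc1`, 351 nM

Among the compounds with values here, in an assay on HEK293 cells for inhibition of Voltage-dependent T-type calcium channel subunit alpha-1H (Homo sapiens), read by patch clamp, using a membrane potential dye (on this read-out higher numbers stand for weaker inhibition and lower numbers for stronger inhibition), compound 2 gives 351 nM, the only number recorded for it; a further entry carries no single number. Compound 1 is harder to place, since the several entries of compound 1 in this assay, 45 nM; 872 nM (2 entries) spans a wide gap between its two entries. Compound 3, `CCC(C)NC(=O)N1CCC2(CC1)C(=O)N(c1cccc(F)c1)C2c1ccc(Cl)cc1`, has not been measured. It differs from compound 2 in one place: sec-butyl in place of 1-phenylethyl on an amide-type nitrogen. Within the data shown here, no directly comparable pair of measured compounds shows what such a swap does here, so the direction is uncertain. The shrinking of the group on the amide-type nitrogen is expected to weaken inhibition somewhat, a step of a 2.3-fold higher number from compound 2 to compound 3 (0.36 log units; beyond the scatter) in this assay, though it may stay within the usual scatter. Compound 3 is therefore estimated at 800 nM, with a likely range from 200 nM to 3000 nM.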

Compound 3, half-maximal inhibitory concentration: 1250 nM
For compound 3 the middle estimate is 1.6-fold (0.19 log units) below the measured one; low and high end bracket the measured number.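

Within the data shown here, the first step that can be read at this amide-type nitrogen in this assay is a 3.6-fold higher number from compound 2 to compound 3 (0.55 log units; beyond the scatter), so swapping 1-phenylethyl for sec-butyl weakens inhibition by more than the usual scatter. The swap takes the group from 8 heavy atoms to 4 and removes its six-membered aromatic ring. Even so, inhibition is not lost altogether, since compound 3 still gives a measured 1250 nM.

This single step cannot separate the loss of the aromatic ring from the loss of size, a question that a cyclohexyl or benzyl group on the same nitrogen could help to answer. How firmly the step can be read is also open, given how far two entries for one compound of this series lie apart: the several entries of compound 1 in this assay, 45 nM; 872 nM (2 entries)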